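Swapping the aryl group on a dichlorophenyl thiazole acid

A few compounds are considered here, and "the series" means these few. Any claim that something is new, unique, unknown or untested is made for them only; others in the source may bear on it.

Within the data shown here, in a functional assay on BJAB cells (Homo sapiens) for antiproliferative activity, with a stated time of 4 days (a higher number here means that more compound is needed for the effect, a lower number that less compound is needed), compound 1 `Cc1nn(-c2nc(-c3ccc(Cl)c(Cl)c3)c(SC(C)C)s2)c(C(=O)O)c1-c1cccc(Cl)c1C` gives 5100 nM, the only measured number available. Compound 2 `Cc1oncc1-c1nc(-n2nc(C(=O)O)c(-c3cc(Cl)cc(Cl)c3)c2C)sc1SC(C)C` gives > 44000 nM in this assay, a limit of the assay rather than a measured number (the limit of > 44000 nM in this assay, at which 1 of the 2 values shown sits). Compound 3 `Cc1nn(-c2nc(-c3ccc(Cl)c(Cl)c3)c(SC(C)C)s2)c(C(=O)O)c1-c1ccccc1C(F)(F)F` differs from compound 1 in one place: 2-(trifluoromethyl)phenyl in place of 3-chloro-2-methylphenyl on an aromatic carbon. Among the measured compounds shown here, no measured step of this kind exists here, so only a modest step of about a 1.6-fold higher number from compound 1 to compound 3 (0.20 log units; within the scatter) toward weaker activity is expected. Compound 3 is therefore estimated at 8000 nM in this assay, within 2500 nM to 30000 nM.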

Compound 3, half-maximal effective concentration: 5200 nM
For compound 3 the middle estimate is 1.5-fold (0.19 log units) above the measured one; the measured number falls inside the stated range.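

In this assay the swap to 2-(trifluoromethyl)phenyl gives a 1.0-fold higher number from compound 1 to compound 3 (0.01 log units; within the scatter), so these two substituted phenyl groups read alike on this aromatic carbon, the one flanked by the ring atoms bearing the carboxy and methyl groups. The position thus accepts a trifluoromethyl group on the phenyl ring in place of the chlorine and methyl pair without a step beyond the scatter. Nothing measured here accounts for this result.

Going by these compounds, whether the position would also accept a phenyl ring carrying an amine, or a pyridine ring, remains open.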